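Swapping a bromophenyl amide for a glycine ester

The source may hold more compounds than are shown below. What is called first, only, known or untested is meant among the compounds shown, and "the series" means these compounds.

Of the compounds shown here, three built on one shared core have been tested in an ADME assay on Huh-7 cells (Homo sapiens) for cytotoxicity, read by a luciferase reporter and WST assay, with a stated time of 3 days; a lower number here means that less compound is tolerated, a higher number that more compound is tolerated. Compound 1, `O=C(Nc1ccc(Br)cc1)c1c(NO)cc(-c2ccccc2)oc1=O`, carries a 4-bromophenyl group on an amide-type nitrogen. In this assay compound 1 reaches only the limit of the measurement, > 20000 nM. Compound 2, `CNC(=O)c1c(NO)cc(-c2ccc(F)cc2)oc1=O`, and compound 3, `CNC(=O)c1c(NO)cc(-c2ccc(Cl)cc2)oc1=O`, instead carry a methyl group on that nitrogen and differ from each other only in the halogen on an aromatic carbon. Compound 2 likewise gives only a limit, > 20000 nM. Compound 3 also gives only a limit, > 20000 nM. Among the measured compounds shown here, the one measured step, a step that the two limits leave unreadable from compound 2 to compound 3, cannot be read; both of its ends sit at a limit. What is known is summed up in the limit of > 20000 nM in this assay, at which 3 of the 3 values shown sit: compound 1 and the two others all rest at that limit.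

Compound 4, `COC(=O)CNC(=O)c1c(NO)cc(-c2ccccc2)oc1=O`, is made from compound 1 by the change ((methoxycarbonyl)methyl in place of 4-bromophenyl on an amide-type nitrogen). For the measured compounds named here, no measured step touches the amide-type nitrogen, so nothing shows how this change moves the read-out. With every value at the limit, the expectation for compound 4 is a step that the limit leaves unreadable from compound 1 to compound 4, that is, nothing readable beyond the scatter. Compound 4 is therefore estimated at 25000 nM, within a range from 10000 nM to 60000 nM, most likely reported again only as a limit.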

Compound 4, half-maximal cytotoxic concentration: > 20000 nM
Compound 4 was reported as a limit; the forecaster's own chance of this, stated with the estimate: 80%; the middle value does not contradict the limit.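

The change from compound 1 to compound 4 gives no readable step, since both compounds rest at a limit of the measurement and not at a number: the limit of > 20000 nM in this assay, at which 4 of the 4 values shown sit. In this assay the compounds shown leave open how much of each is actually tolerated, and whether changing the group on the amide-type nitrogen shifts that amount at all.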